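Methyl on the Shared Core

The compounds below may be only part of what the source reports. "The series", "measured", "known", "first", "only" and "open" are said of these compounds alone.

Compound 1 `[O-][n+]1cccc(Oc2ccccc2)c1` was tested in a functional assay on the whole organism with Mus musculus as the target, in the maximal electroshock model, with a stated time of 30 min (on this read-out higher numbers stand for an effect only at larger amounts of compound and lower numbers for an effect already at smaller amounts), and gives 100 mg/kg, the highest of the two numbers measured here. Its nearest neighbour is compound 2 `Cc1cc[n+]([O-])cc1Oc1ccccc1`, which in this assay gives 30 mg/kg, a step of a 3.3-fold lower number from compound 1 to compound 2 (0.52 log units; beyond the scatter).

Compound 3 `Cc1cc(Oc2ccccc2)c[n+]([O-])c1` has not yet been measured in this assay. It differs from compound 1 by methyl in place of hydrogen on an aromatic carbon. For the measured compounds named here, the only measured step that bears on this change is the one from compound 1 to compound 2, which also adds a methyl to the core, at a different place, and lowered the number by a 3.3-fold lower number from compound 1 to compound 2 (0.52 log units; beyond the scatter). On that basis a step toward lower numbers is expected for compound 3 too, of similar or somewhat smaller size, so that the expected step is a 2.2-fold lower number from compound 1 to compound 3 (0.35 log units; beyond the scatter). The estimated value for compound 3 in this assay is therefore 45 mg/kg, within a range from 20 mg/kg to 100 mg/kg.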

Compound 3, minimum effective dose: 100 mg/kg
Compound 3: the middle estimate sits 2.2-fold (0.35 log units) below what was measured, and the stated range covers the measured number.
By their numbers in this assay, from the lowest: compound 2; then compounds 1 and 3 (each within the scatter of the next).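

In this assay the step for methyl in place of hydrogen, two atoms from the ring nitrogen, is no change at the digits printed from compound 1 to compound 3 (within the scatter) and so does not repeat the earlier methyl step on another aromatic carbon of the shared core, which was a 3.3-fold lower number from compound 1 to compound 2 (0.52 log units; beyond the scatter). Compound 2 alone had suggested that a methyl on this core might lower the number wherever it sits, but compound 3 shows that the result depends on the place of the methyl. Nothing available explains why the two places differ.

Going by these compounds, whether a longer chain such as ethyl, or an amine or a methoxy group, would change the number at this same place remains open. The compounds also leave open how chlorine on the outer phenyl ring would affect the number, with or without a methyl on the core.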